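The source may report more compounds than this note shows. Statements on the series, on what has been measured and on what is new or still open speak of the compounds shown alone.

Measured in a functional assay on MDA-MB-231 cells (Homo sapiens) for antiproliferative activity, read by MTT assay, with a stated time of 24 h; a higher number here means a weaker inhibitor, a lower number a stronger inhibitor:
Compound 1 `COc1ccc(-c2noc(-c3ccncc3)n2)cc1OC1CCCC1`: 240000 nM
Compound 2 `Fc1ccc(-c2nc(-c3ccccc3)no2)cc1`: > 1000000 nM

Compound 2 gives only a limit of the assay, > 1000000 nM, and not a number. Going by the values given here, that leaves compound 1, at 240000 nM, as the only actual number in this assay, so it has no measured neighbour to be ranked against.

Compound 3 `COc1ccc(-c2noc(-c3cccnc3)n2)cc1OC1CCCC1` has the same atoms as compound 1, joined differently, with pyridin-3-yl in place of pyridin-4-yl on an aromatic carbon. Among the compounds with values here, no measured pair shows what such a swap does. The expectation therefore rests on compound 1 alone, at 240000 nM, and no change beyond the usual scatter is expected, in either direction. The estimated step is a 1.0-fold higher number from compound 1 to compound 3 (0.02 log units; within the scatter). Compound 3 is expected to read 250000 nM, within an estimated range from 100000 nM to 600000 nM.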

Compound 3, half-maximal inhibitory concentration: > 1000000 nM
Compound 3: no number, only a limit; the forecaster's own chance of this, stated with the estimate: 20%; at least 4.0-fold (0.60 log units) between middle value and limit.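

In this assay, the swap of pyridin-4-yl for pyridin-3-yl on this aromatic carbon keeps the same atoms, joined differently, yet gives an at least 4.1-fold higher number from compound 1 to compound 3 (0.61 log units; beyond the scatter). Going by these compounds alone, this is the first sign that activity at this place depends on where the nitrogen sits in the pyridine ring, and not just on the ring being present. Compound 3 gives only a limit of the assay and not a number, so the step fixes a minimum size and no more: the limit of > 1000000 nM in this assay, at which 2 of the 3 values shown sit.

What the compounds shown leave open is how large the true step is, and whether it would hold on a core other than that of compound 1. They also leave open whether pyridin-2-yl at this place, or an amine or a carboxylic acid on the pyridine ring, would read lower than compound 1.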